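Swapping a triazole for a pyrazole in a sulfonyl hydrazide

The source may report more compounds than this note shows. Statements on the series, on what has been measured and on what is new or still open speak of the compounds shown alone.

Compound 1 `Cc1cc(-n2nccn2)cc(C(=O)NNS(=O)(=O)c2ccccc2)c1F` is a sulfonyl hydrazide carrying a methyl-fluorophenyl core with a 2H-1,2,3-triazol-2-yl group. In an ADME assay on Caco-2 cells (Homo sapiens) for permeability, read by LC-MS, in the apical to basolateral direction, with a stated time of 90 min (on this read-out higher numbers stand for higher permeability and lower numbers for lower permeability), compound 1 gives 53 10^-6 cm/s. Within the data shown here, the only other compound measured, compound 2 `O=C(NNS(=O)(=O)c1ccccc1F)c1cccc(-c2ccco2)c1`, gives 55.3 10^-6 cm/s in this assay, so the two numbers lie within the usual scatter of each other and neither can be called more or less permeable than the other. Compound 3 `Cc1cc(-n2cccn2)cc(C(=O)NNS(=O)(=O)c2ccccc2)c1F` has not yet been measured; it differs from compound 1 by a single change: 1H-pyrazol-1-yl in place of 2H-1,2,3-triazol-2-yl on an aromatic carbon. Among the measured compounds shown here, no measured pair shows what this swap does in this assay. Both measured compounds already sit at high permeability, so the step from compound 1 to compound 3 is expected to be small, a 1.1-fold higher number from compound 1 to compound 3 (0.05 log units; within the scatter), in no direction beyond the scatter. Compound 3 is therefore estimated at 60 10^-6 cm/s, with a likely range from 35 10^-6 cm/s to 100 10^-6 cm/s.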

Compound 3, apparent permeability: 48 10^-6 cm/s
Compound 3: middle estimate off by 1.3-fold (0.10 log units), on the high side, within the range that was stated.
By their numbers in this assay, from the lowest: compounds 3, 1 and 2 (each within the scatter of the next).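

Among these compounds, this gives the first direct pair at this position, an aromatic carbon para to a fluoro group and meta to a methyl group: in this assay, 1H-pyrazol-1-yl in place of 2H-1,2,3-triazol-2-yl gives a 1.1-fold lower number from compound 1 to compound 3 (0.04 log units; within the scatter). A five-membered aromatic ring with 2 hetero atoms and one with 3 hetero atoms therefore cannot be told apart on this read-out when the rest of the molecule stays the same. Nothing measured here speaks to the reason for this result.

The compounds shown leave open whether a different kind of group on this same carbon, such as an amine, a carboxylic acid or a longer chain, would shift the number beyond the scatter. They also leave open whether the same swap would read alike on a different core.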